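Inverting One Stereocentre in a Fluorinated Alcohol

This account rests on a few compounds, and the source may have more. Where it says the series, first, only, none or still open, it means among the compounds named here.

Three fluorinated alcohols have been measured in a physicochemical assay for lipophilicity, read by NMR; a lower number here means a more polar compound, a higher number a more lipophilic compound. Compound 1 `CC(O)CC(C)(F)F` gives 0.66, compound 2 `CC(O)CCCF` gives 0.42, and compound 3 `CC[C@@H](F)[C@H](C)O` gives 0.68. The number for compound 3 lies within the usual scatter of that of compound 1 and also of that of compound 2, so these three cannot be set apart on what has been measured. Compound 4 `CC[C@H](F)[C@H](C)O` has not been measured. From compound 3 to compound 4 the change is the two compounds have the same atoms and bonds and differ only in configuration as drawn: 1 of 2 stereo elements differ; a stereocentre at a saturated chain carbon is drawn R in compound 3 and S in compound 4. Within the data shown here, no measured pair in this set shows such a change. The atoms and bonds are unchanged, and the step of no change at the digits printed from compound 3 to compound 4 (within the scatter) in this assay is expected to stay within the scatter, in no set direction. Compound 4 is estimated at 0.68, with a range from 0.4 to 0.96.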

Compound 4, partition coefficient: 0.68
Beside the measured number, compound 4's estimate shows no gap at the digits printed, within the range that was stated.
By their numbers in this assay, from the lowest: compounds 2, 1, 3 and 4 (each within the scatter of the next).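

In this assay, inverting the stereocentre at a saturated chain carbon gives no change at the digits printed from compound 3 to compound 4 (within the scatter). Among these compounds, this is the only measured pair in the set in which configuration alone changes, with the second stereo element held as drawn. The step can be read for that inversion and nothing else because of one fact: the fact that compounds 3 and 4 differ only in the configuration as drawn.

The compounds shown leave open whether inverting the second stereo element, or both together, would give a similar step. They also leave open whether the same inversion would give a similar step in a compound with a longer chain or an amine.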